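From 2-Fluorophenyl to 4-Hydroxyphenyl on an Amide

This account rests on a few compounds, and the source may have more. Where it says the series, first, only, none or still open, it means among the compounds named here.

In a functional assay on OVCAR-5 cells (Homo sapiens) for inhibition, read by CCK-8 assay, with a stated time of 72 h, tested at 1 uM (on this read-out higher numbers stand for more inhibition of growth at the one concentration tested and lower numbers for less inhibition of growth), compound 1 (`CN(C)C(=O)c1cc2cnc(Nc3ccc(NC(=O)C4(C(=O)Nc5ccc(F)cc5)CC4)cc3)nc2n1C1CCCC1`) gives 65.4%, and compound 3 (`CN(C)C(=O)c1cc2cnc(Nc3ccc(NC(=O)C4(C(=O)Nc5ccccc5F)CC4)cc3)nc2n1C1CCCC1`) gives 58%. These two values lie within the usual scatter of each other. Compound 2 (`CN(C)C(=O)c1cc2cnc(Nc3ccc(N)cn3)nc2n1C1CCCC1`) gives 12.3%, a much lower number that sits beyond the scatter from compound 3.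

Compound 4 (`CN(C)C(=O)c1cc2cnc(Nc3ccc(NC(=O)C4(C(=O)Nc5ccc(O)cc5)CC4)cc3)nc2n1C1CCCC1`) is still unmeasured. It carries 4-hydroxyphenyl in place of 2-fluorophenyl on an amide-type nitrogen. Among the measured compounds shown here, only one measured step bears on this place: a number 7.4 percentage points lower from compound 1 to compound 3 (within the scatter), where 2-fluorophenyl replaced 4-fluorophenyl. For the measured compounds named here, that swap stayed within the scatter, but it involved only fluorophenyl groups, and no measured compound has a hydroxyphenyl group here. The evidence is therefore thin, and the range must stay wide. No change beyond the scatter is expected, and the estimate is a number 3 percentage points lower from compound 3 to compound 4 (within the scatter). In this assay, compound 4 is expected to give about 55%, with an estimated range of 37% to 71%.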

Compound 4, percent growth inhibition at one concentration: 80.7%
For compound 4 the middle estimate is 25.7 percentage points below the measured one; measured number outside the range, above it.
By their numbers in this assay, from the lowest: compound 2; then compounds 3 and 1 (each within the scatter of the next); then compound 4.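

In this assay the group on this amide-type nitrogen can shift the result beyond the scatter, as 4-hydroxyphenyl in place of 2-fluorophenyl gives a number 22.7 percentage points higher from compound 3 to compound 4 (beyond the scatter) in this comparison, while the earlier swap between the two fluorophenyl groups did not. Hydroxy in place of fluoro on an aromatic carbon, the smaller change, gives a number 15.3 percentage points higher from compound 1 to compound 4 (beyond the scatter) as well, so compound 4 stands apart from both fluorophenyl compounds. No measurement here explains why this change raises the growth inhibition.

Going by these compounds, how a 4-methoxyphenyl or 4-aminophenyl group on this nitrogen would compare with the 4-hydroxyphenyl group stays open. Also open, on these data alone, is whether a 2-hydroxyphenyl group would stand as high as the 4-hydroxyphenyl group of compound 4.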